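Series notes: acid dissociation across the benzylamine variants

The compounds below may be only part of what the source reports. "The series", "measured", "known", "first", "only" and "open" are said of these compounds alone.

Measured so far:
compound 1 `COc1cccc(Oc2ccc3c(NCCCNCc4cc(F)ccc4OC)ccnc3c2)c1` gives 9.28
compound 2 `COc1ccc(F)cc1CNCCCNc1ccnc2cc(CCc3ccccc3)ccc12` gives 9.47
compound 3 `FC(F)(F)c1ccc(-c2ccc3c(NCCCNCc4ccco4)ccnc3c2)cc1` gives 9.47

In a physicochemical assay for acid dissociation, compound 3 stands level with compound 2 at the digits shown, and together they are the highest of the three numbers; compound 1 sits lower, but within the scatter, so no order can be read among the three. For the measured compounds named here, the one measured step, a number 0.19 log units higher from compound 1 to compound 2 (within the scatter), concerns the group on the aromatic carbon of the core and lies within the scatter.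

Compound 4 `COc1ccc(F)cc1CNCCCNc1ccnc2cc(-c3ccc(C(F)(F)F)cc3)ccc12` keeps the core of compound 3 and differs only at the amine end: 5-fluoro-2-methoxyphenyl in place of furan-2-yl on a saturated chain carbon bound to an amine nitrogen. Going by the values given here, no measured step bears on this change directly. What is known is that compounds 1 and 2, which carry the entering group, and compound 3, which carries the leaving group, all fall within a narrow band of each other in this assay. Compound 4 is therefore expected to show a number 0.02 log units lower from compound 3 to compound 4 (within the scatter), no step beyond the scatter. For compound 4 the estimate is 9.45, between 9.1 and 9.8.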

Compound 4, acid dissociation constant: 9.47
Estimate against measurement, compound 4: 0.02 log units below; the range from low to high includes it.
By their numbers in this assay, from the lowest: compounds 1, 2, 3 and 4 (each within the scatter of the next).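

In this assay, for the compounds shown here, 5-fluoro-2-methoxyphenyl in place of furan-2-yl on a saturated chain carbon bound to an amine nitrogen gives no change at the digits printed from compound 3 to compound 4 (within the scatter), a direct reading of this change that the earlier compounds did not provide. With the amine end held constant, 4-(trifluoromethyl)phenyl on the aromatic carbon gives no change at the digits printed from compound 2 to compound 4 (within the scatter) against phenethyl and a number 0.19 log units higher from compound 1 to compound 4 (within the scatter) against 3-methoxyphenoxy, so none of these three groups can be told apart at that place. No evidence on the origin of these readings is at hand.

Still open, from the compounds shown here alone, is whether a carboxylic acid or a tertiary amine on the aromatic carbon would leave the reading within the scatter. The same question stands for an aliphatic amine in place of the 5-fluoro-2-methoxyphenyl group, and for a longer chain linking the two amine nitrogens.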